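The compounds below may be only part of what the source reports. "The series", "measured", "known", "first", "only" and "open" are said of these compounds alone.

Compound 1 `Cc1c(C(C)c2c(F)cccc2F)nc(Nc2ccc(C#N)cc2)[nH]c1=O` gives 1060 nM in an ADME assay on MT4 cells (Homo sapiens) for cytotoxicity, read by MTT assay; a higher number here means that more compound is tolerated, a lower number that less compound is tolerated.
Compound 2 `CC(c1cc(=O)[nH]c(Nc2ccc(C#N)cc2)n1)c1c(F)cccc1F` gives > 2830 nM, which is a limit of the assay and not a number.
Compound 3 `Cc1c(N)nc(Nc2ccc(C#N)cc2)nc1C(C)c1c(F)cccc1F` gives 40500 nM.

The change from compound 1 to compound 2 is hydrogen in place of methyl on an aromatic carbon. It brings an at least 2.6-fold higher number from compound 1 to compound 2 (0.42 log units; beyond the scatter), and this step is known only as a lower bound because of the limit of > 2830 nM in this assay, at which 1 of the 3 values shown sits. Compound 3 stands highest of the two numbers; its nearest neighbour is compound 1, whose number is lower, a gap beyond the scatter. The difference between the core of compound 3 and the core of compound 1 is not broken down here.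

Compound 4 `CC(c1cc(N)nc(Nc2ccc(C#N)cc2)n1)c1c(F)cccc1F` has not been measured. It differs from compound 3 by hydrogen in place of methyl on an aromatic carbon. This is the same kind of change as that from compound 1 to compound 2, not the same: around the place there the group of 1 heavy atom is unspecified, whereas here it is an amino group (1 heavy atom). Resting on the step from compound 1 to compound 2 an at least 2.6-fold higher number from compound 1 to compound 2 (0.42 log units; beyond the scatter), a step of a 1.6-fold higher number from compound 3 to compound 4 (0.21 log units; within the scatter) is expected in this assay, starting from the high value of compound 3 40500 nM. Compound 4 is therefore estimated at 65000 nM, likely between 25000 nM and 160000 nM.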

Compound 4, half-maximal cytotoxic concentration: 46100 nM
Compound 4: middle estimate off by 1.4-fold (0.15 log units), on the high side, and the stated range covers the measured number.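

In this assay, hydrogen in place of methyl on the core that carries the amino group brings a 1.1-fold higher number from compound 3 to compound 4 (0.06 log units; within the scatter), so on this core the change makes no difference that can be read. Set beside the earlier case on the core that carries the carbonyl, the two results cannot yet be called different: the same change on two cores in this assay, an at least 2.6-fold higher number (0.42 log units; beyond the scatter) from compound 1 to compound 2 and a 1.1-fold higher number (0.06 log units; within the scatter) from compound 3 to compound 4; the limit leaves it open whether they differ This shows that the step seen on one core does not have to reappear beyond the scatter on another, but it does not show that the core sets the size of the step, because the earlier step is known only as a lower bound: the limit of > 2830 nM in this assay, at which 1 of the 4 values shown sits.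

The compounds shown leave open what an ethyl group or a chlorine atom would do at this place on an aromatic carbon, on either core. They also leave open how the same change behaves on a core with a methoxy group in place of the amino group or the carbonyl, since two pairs are too few to show a trend.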